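The source may hold more compounds than are shown below. What is called first, only, known or untested is meant among the compounds shown, and "the series" means these compounds.

Three compounds have been measured in a functional assay on HT-29 cells (Homo sapiens) for antiproliferative activity, read by XTT assay, with a stated time of 72 h; on this read-out higher numbers stand for weaker inhibition and lower numbers for stronger inhibition:

Compound 1, `C=C(C)CCC[C@]1(C)C2=CCC[C@](C)(C[C@H](O)C3=CC(=O)OC3O)[C@H]2CC[C@H]1C`, gives 3000 nM.
Compound 2, `C=C(C)CCC[C@]1(C)C2=CCC[C@](C)(C[C@@H](O)c3ccoc3)[C@H]2CC[C@H]1C`, gives 63100 nM.
Compound 3, `C=C(C)CC[C@]1(C)C2=CCC[C@](C)(C[C@H](O)C3=CC(=O)OC3O)[C@H]2CC[C@H]1C`, gives 3200 nM.

Compound 2 differs from compound 1 by a group of 7 heavy atoms (5 carbon, 2 oxygen; one five-membered aromatic ring with 1 hetero atom) in place of a group of 9 heavy atoms (5 carbon, 4 oxygen; one five-membered non-aromatic ring with 1 hetero atom), on a saturated chain carbon bound to a saturated ring carbon, and in this assay this step is a 21-fold higher number from compound 1 to compound 2 (1.32 log units; beyond the scatter). Compound 3 differs from compound 1 only in the core, by 1-methylethenyl in place of 2-methylprop-2-en-1-yl on a saturated chain carbon, two bonds along the chain from a saturated ring carbon, and that step is a 1.1-fold higher number from compound 1 to compound 3 (0.03 log units; within the scatter), so the two cores give much the same number in this assay.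

Compound 4, `C=C(C)CC[C@]1(C)C2=CCC[C@](C)(C[C@@H](O)c3ccoc3)[C@H]2CC[C@H]1C`, has not yet been measured. Going by the values given here, it differs from compound 3 by a group of 7 heavy atoms (5 carbon, 2 oxygen; one five-membered aromatic ring with 1 hetero atom) in place of a group of 9 heavy atoms (5 carbon, 4 oxygen; one five-membered non-aromatic ring with 1 hetero atom), on a saturated chain carbon bound to a saturated ring carbon, the same change as the one between compound 1 and compound 2, now made on the core of compound 3. Given a 1.1-fold higher number from compound 1 to compound 3 (0.03 log units; within the scatter), the two cores are taken to behave alike, and the change is expected to carry over at about its earlier size. For compound 4 the expected step is a 20-fold higher number from compound 3 to compound 4 (1.31 log units; beyond the scatter), resting on a 21-fold higher number from compound 1 to compound 2 (1.32 log units; beyond the scatter). Compound 4 is therefore estimated at 65000 nM, within a range from 25000 nM to 170000 nM.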

Compound 4, half-maximal inhibitory concentration: 30000 nM
Estimate against measurement, compound 4: 2.2-fold (0.34 log units) above, and the stated range covers the measured number.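

Made on the second core, the exchange for (furan-3-yl)(hydroxy)methyl again weakens inhibition in this assay, with a 9.4-fold higher number from compound 3 to compound 4 (0.97 log units; beyond the scatter), and the size of this step does not differ from that on the first core: the same change on two cores in this assay, a 21-fold higher number (1.32 log units; beyond the scatter) from compound 1 to compound 2 and a 9.4-fold higher number (0.97 log units; beyond the scatter) from compound 3 to compound 4, 2.2-fold (0.35 log units) apart, within the scatter of two such steps. Read the other way, swapping 2-methylprop-2-en-1-yl for 1-methylethenyl among the furan-bearing pair gives a 2.1-fold lower number from compound 2 to compound 4 (0.32 log units; beyond the scatter), a step that likewise cannot be told apart from its counterpart in the other pair: the same change on two cores in this assay, a 1.1-fold higher number (0.03 log units; within the scatter) from compound 1 to compound 3 and a 2.1-fold lower number (0.32 log units; beyond the scatter) from compound 2 to compound 4, 2.2-fold (0.35 log units) apart, within the scatter of two such steps. The change therefore carries over between these two cores in direction and, within the scatter, in size, but this is one comparison of two cores, and it shows neither that the change would transfer to any other core nor why the number moves.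

On these data alone, what a carboxylic acid or an amine would do in place of these groups, on the same saturated chain carbon, remains open. So does the effect of a longer chain in place of 2-methylprop-2-en-1-yl.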